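Nitro for fluorine on the imine-bearing aryl ring

This account rests on a few compounds, and the source may have more. Where it says the series, first, only, none or still open, it means among the compounds named here.

In a functional assay on MCF7 cells (Homo sapiens) for cytotoxicity, read by sulforhodamine B assay, with a stated time of 48 h (a higher number here means a weaker inhibitor, a lower number a stronger inhibitor), compound 1 `COc1ccc(C2C(C#N)=C(/N=C/c3ccccc3)Oc3nc(Nc4ccc(S(N)(=O)=O)cc4)sc32)cc1` gives 33600 nM. Compound 2 `COc1ccc(C2C(C#N)=C(/N=C/c3ccc(Cl)cc3)Oc3nc(Nc4ccc(S(N)(=O)=O)cc4)sc32)cc1` gives 9550 nM in this assay. Compound 3 `COc1ccc(C2C(C#N)=C(/N=C/c3ccc(F)cc3)Oc3nc(Nc4ccc(S(N)(=O)=O)cc4)sc32)cc1` gives 28900 nM in this assay, which places it second highest of the three, close to compound 1 and further from compound 2. The step from compound 1 to compound 3 was a 1.2-fold lower number from compound 1 to compound 3 (0.07 log units; within the scatter), from compound 1 to compound 2 a 3.5-fold lower number from compound 1 to compound 2 (0.55 log units; beyond the scatter), and from compound 2 to compound 3 a 3.0-fold higher number from compound 2 to compound 3 (0.48 log units; beyond the scatter). Compound 4 `COc1ccc(C2C(C#N)=C(/N=C/c3ccc([N+](=O)[O-])cc3)Oc3nc(Nc4ccc(S(N)(=O)=O)cc4)sc32)cc1` carries the change (nitro in place of fluoro on an aromatic carbon). No measured step involves a nitro group, so the expectation rests on the modest shifts seen among these halogens and hydrogen. Compound 4 is expected to give 15000 nM (range 6000 nM to 40000 nM), a step of a 1.9-fold lower number from compound 3 to compound 4 (0.28 log units; within the scatter) estimated downward but modest.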

Compound 4, half-maximal inhibitory concentration: 9700 nM
Compound 4: the middle estimate sits 1.5-fold (0.19 log units) above what was measured; the range from low to high includes it.
By their numbers in this assay, from the lowest: compounds 2 and 4 (each within the scatter of the next); then compounds 3 and 1 (each within the scatter of the next).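

In this assay, the change from 4-fluorophenyl to 4-nitrophenyl brings a 3.0-fold lower number from compound 3 to compound 4 (0.47 log units; beyond the scatter), so this position also responds to a group that is not a halogen. Nitro and chloro stand level, with a 1.0-fold higher number from compound 2 to compound 4 (0.01 log units; within the scatter), and nitro also differs from hydrogen, with a 3.5-fold lower number from compound 1 to compound 4 (0.54 log units; beyond the scatter), so two different groups reach the same level while fluoro does not. Nothing available here accounts for why these two groups coincide.

Going by these compounds, whether an amine or a carboxylic acid on this aromatic carbon would reach that same level stays open. So does whether nitro would give the same result on another carbon of this ring.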